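Sulfanyl series on a shared enone core: towards compound 4

The compounds below may be only part of what the source reports. "The series", "measured", "known", "first", "only" and "open" are said of these compounds alone.

Three compounds of this series have been run in a functional assay on DU-145 cells (Homo sapiens) for inhibition, read by trypan blue exclusion, with a stated time of 96 h; a higher number here means a weaker inhibitor of growth, a lower number a stronger inhibitor of growth. Compound 1 `Cc1ccc(S/C(=C/c2ccc(Br)cc2)C(=O)c2ccc(Cl)cc2)cc1` gives 25000 nM. Within the data shown here, compound 2 `Cc1ccc(S/C(=C/c2ccc[nH]2)C(=O)c2ccc(Cl)cc2)cc1` gives 10000 nM, and the step of a 2.5-fold lower number from compound 1 to compound 2 (0.40 log units; beyond the scatter) is the only single-place change measured so far; it alters the group on the double-bonded chain carbon, not the sulfur substituent. Compound 3 `O=C(/C(=C\c1c(O)cc(O)cc1O)SCc1ccc(Cl)cc1Cl)c1ccc(Cl)cc1` gives 25000 nM, level with compound 1 at the digits shown, so compound 3 and compound 1 together sit at the top of the three numbers, with compound 2 the lowest.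

The next compound, compound 4 `Cc1ccc(S/C(=C/c2c(O)cc(O)cc2O)C(=O)c2ccc(Cl)cc2)cc1`, differs from compound 3 in one place: 4-methylphenyl in place of 2,4-dichlorobenzyl on a sulfur. Among the measured compounds shown here, no measured step touches the sulfur substituent, so the step from compound 1 to compound 2 does not bear directly on this change, and nothing measured speaks for or against it. What compound 4 shares with compound 1 and compound 2 is the (4-methylphenyl)sulfanyl group, and those two compounds sit in the same narrow band as compound 3. The step of a 1.3-fold lower number from compound 3 to compound 4 (0.10 log units; within the scatter) is therefore expected to be small, not clearly beyond the scatter in either direction. For compound 4 the estimate in this assay is 20000 nM, with a range from 7000 nM to 50000 nM.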

Compound 4, concentration for 50% growth inhibition: > 100000 nM
Compound 4 gave a limit, no number; the forecaster's own chance of this, stated with the estimate: 20%; at least 5.0-fold (0.69 log units) between middle value and limit.
By their numbers in this assay, from the lowest: compound 2; then compounds 1 and 3 (each within the scatter of the next). At a limit, above all of these: compound 4.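

In this assay compound 4 stands at a limit of the assay, not a number: the limit of > 100000 nM in this assay, at which 1 of the 4 values shown sits.

Among these compounds, this is the first measured change at the sulfur substituent, and it is not silent: 4-methylphenyl in place of 2,4-dichlorobenzyl on a sulfur gives an at least 4.0-fold higher number from compound 3 to compound 4 (0.60 log units; beyond the scatter), so with 2,4,6-trihydroxyphenyl on the double-bonded chain carbon, the group on sulfur matters. With (4-methylphenyl)sulfanyl held constant, the group on the double-bonded chain carbon also counts, more than the earlier step alone showed: 2,4,6-trihydroxyphenyl in place of 4-bromophenyl gives an at least 4.0-fold higher number from compound 1 to compound 4 (0.60 log units; beyond the scatter), and in place of 1H-pyrrol-2-yl it gives an at least 10-fold higher number from compound 2 to compound 4 (1.00 log units; beyond the scatter).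

The true size of these three steps stays open, since each rests on a limit, and the compounds shown do not tell whether the sulfur change would act alike with 4-bromophenyl or 1H-pyrrol-2-yl on the chain carbon. Nor do they say how a plain benzyl, a 4-chlorobenzyl or an amine-bearing chain on the sulfur would read, so the separate roles of the methylene link and the chlorines in 2,4-dichlorobenzyl remain unresolved.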